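Halogen swap on two benzofuran amidoxime cores

A few compounds are considered here, and "the series" means these few. Any claim that something is new, unique, unknown or untested is made for them only; others in the source may bear on it.

Measured so far:
compound 1 `O/N=C(/Nc1ccc(F)c(Cl)c1)c1ccc2occc2c1` 1800 nM
compound 2 `O/N=C(/Nc1ccc(F)c(Br)c1)c1ccc2occc2c1` 2600 nM
compound 3 `OCc1cc2cc(/C(=N\O)Nc3cccc(Cl)c3)ccc2o1` 5900 nM

In an assay on tissue (HeLa cells) for inhibition of Indoleamine 2,3-dioxygenase 1 (Homo sapiens), read by spectrophotometry (a higher number here means a weaker inhibitor, a lower number a stronger inhibitor), compound 1 gives 1800 nM and compound 2 gives 2600 nM. The change bromo in place of chloro on an aromatic carbon made the step of a 1.4-fold higher number from compound 1 to compound 2 (0.16 log units; within the scatter). The core of compound 3 differs from the core of compound 1 in more than one place; that difference is not broken down here. Compound 4 `OCc1cc2cc(/C(=N\O)Nc3cccc(Br)c3)ccc2o1` is not yet measured. The change bromo in place of chloro on an aromatic carbon is the same kind of change as the earlier one, but its place differs: in the earlier pair the aromatic carbon is also ortho to a fluoro group, whereas here it is only meta to a large group. The step for compound 4 is expected to be a 1.3-fold higher number from compound 3 to compound 4 (0.10 log units; within the scatter), resting on compound 1 and compound 2 and their step of a 1.4-fold higher number from compound 1 to compound 2 (0.16 log units; within the scatter). Compound 4 is estimated at 7500 nM, with a range of 3500 nM to 16000 nM.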

Compound 4, half-maximal inhibitory concentration: 1200 nM
For compound 4 the middle estimate is 6.3-fold (0.80 log units) above the measured one, and the stated range ends above it.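

In this assay, the 3-chlorophenyl to 3-bromophenyl change on the core of compound 3 gives a 4.9-fold lower number from compound 3 to compound 4 (0.69 log units; beyond the scatter). Bromo in place of chloro therefore does not carry over as one fixed step between these two cores: the same change on two cores in this assay, a 1.4-fold higher number (0.16 log units; within the scatter) from compound 1 to compound 2 and a 4.9-fold lower number (0.69 log units; beyond the scatter) from compound 3 to compound 4, 7.1-fold (0.85 log units) apart, beyond the scatter of two such steps

The two pairs differ in the core and also in the fluoro group present in compound 1 and compound 2, so these compounds do not show which difference separates the steps, and one pair per core supports no general rule.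

As far as these compounds go, it remains open whether iodo or methyl in the same place would follow bromo on the core of compound 3. Also open, from the compounds shown here alone, is whether the step would hold with a fluoro group added to that ring, or with an amine or a carboxylic acid in place of the hydroxymethyl group.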